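Thiosemicarbazone Series at the Cytotoxicity Limit: A Chlorophenyl Variant

The source may report more compounds than this note shows. Statements on the series, on what has been measured and on what is new or still open speak of the compounds shown alone.

Compound 1 `CC1=CC[C@@H]([C@@](C)(O)CCCC(C)(C)NC(=S)N/N=C\c2ccc(C)cc2)CC1` carries a 4-methylphenyl group on the carbon with a double bond to nitrogen. In a functional assay on HT-29 cells (Homo sapiens) for cytotoxicity, read by sulforhodamine B assay (on this read-out lower numbers stand for higher toxicity in this test and higher numbers for lower toxicity in this test), compound 1 gives > 100000 nM, which is a limit of the assay rather than a number. Compound 2 `CC1=CC[C@@H]([C@@](C)(O)CCCC(C)(C)NC(=S)N/N=C\c2ccc(N(C)C)cc2)CC1` differs by dimethylamino in place of methyl on an aromatic carbon, and in this assay compound 2 likewise gives > 100000 nM, again a limit. Compound 3 `CC1=CC[C@@H]([C@@](C)(O)CCCC(C)(C)NC(=S)N/N=C\c2cccc([N+](=O)[O-])c2)CC1` puts 3-nitrophenyl in place of 4-methylphenyl on the carbon with a double bond to nitrogen, and in this assay compound 3 also gives > 100000 nM, a limit. The steps a step that the two limits leave unreadable from compound 1 to compound 2 and a step that the two limits leave unreadable from compound 1 to compound 3 therefore have no readable size, and the same holds for a step that the two limits leave unreadable from compound 2 to compound 3. What unites the series is the limit of > 100000 nM in this assay, at which 3 of the 3 values shown sit.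

Compound 4 `CC1=CC[C@@H]([C@@](C)(O)CCCC(C)(C)NC(=S)N/N=C\c2ccccc2Cl)CC1` is not yet measured. It differs from compound 1 by 2-chlorophenyl in place of 4-methylphenyl on a carbon with a double bond to nitrogen. The measured steps offer no direction because every value sits at the limit of > 100000 nM in this assay, at which 3 of the 3 values shown sit. On that basis compound 4 is expected to differ by a step that the limit leaves unreadable from compound 1 to compound 4, most likely no readable change. Compound 4 is therefore estimated to show 150000 nM in this assay, within a range from 50000 nM to 500000 nM, with the result most probably again reported only as a limit.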

Compound 4, concentration lethal to 50% of the cells: > 100000 nM
Compound 4: a limit, no number (the forecaster's own chance of this, stated with the estimate: 85%); the middle value lies beyond the limit too.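

Among the compounds shown here, with compound 4 the series stays at the limit, so no step from compound 1, compound 2 or compound 3 to compound 4 can be read in this assay: the limit of > 100000 nM in this assay, at which 4 of the 4 values shown sit. The compounds shown leave open whether any of them differ in toxicity, and whether any other aromatic group on the shared core would give a measurable value in this assay.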